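Swapping methoxy for methyl in compound 1

The source may hold more compounds than are shown below. What is called first, only, known or untested is meant among the compounds shown, and "the series" means these compounds.

For the measured compounds named here, in a functional assay on KB 3-1 cells (Homo sapiens) for cytotoxicity, read by MTT assay, with a stated time of 68 h (on this read-out higher numbers stand for weaker inhibition and lower numbers for stronger inhibition), compound 1 (`COc1cccc(-c2cccc(NC(=O)C(Cl)Cl)c2)c1`) gives 43300 nM, the higher of the two exact numbers so far. Compound 3 (`CCOc1cccc(-c2cc(NC(=O)C(Cl)Cl)cc(-c3cccc(OCC)c3)c2)c1`) gives a lower number, 14800 nM. Compound 2 (`COc1cccc(-c2cc(NC(=O)C(Cl)Cl)cc(-c3cccc(OC)c3)c2)c1`) returns a limit rather than an exact number, > 30000 nM.

The next compound, compound 4 (`Cc1cccc(-c2cccc(NC(=O)C(Cl)Cl)c2)c1`), keeps the core of compound 1 and changes one group, with methyl in place of methoxy on an aromatic carbon. Going by the values given here, the only measured step, a step that the limit leaves unreadable from compound 1 to compound 2, cannot be sized and involves a different change, so it offers no guide to this swap. Among the compounds with values here, no measured step exchanges these two groups, so the expectation stays near compound 1 at 43300 nM, with no step beyond the scatter in this assay. The estimated step is a 1.4-fold lower number from compound 1 to compound 4 (0.16 log units; within the scatter), which lies within the usual scatter. For compound 4 the expected value is 30000 nM, with an estimated range from 12000 nM to 80000 nM.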

Compound 4, half-maximal inhibitory concentration: > 50000 nM
Compound 4: a limit, no number (the forecaster's own chance of this, stated with the estimate: 25%); middle value at least 1.6-fold (0.22 log units) away from the limit.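

Compound 4 returns only a limit, not an exact number: the limit of > 50000 nM in this assay, at which 1 of the 4 values shown sits.

In this assay, for the compounds shown here, exchanging methoxy for methyl on an aromatic carbon, meta to a large group, gives the first readable step at this place, an at least 1.1-fold higher number from compound 1 to compound 4 (0.06 log units; that floor lies within the scatter), so methyl brings no lower number here than methoxy does. Only the floor of that step is known, and that floor lies within the scatter, so the real gap could be small or much larger.

As far as these compounds go, how far the number would move with an amine or a hydroxyl on the same aromatic carbon stays open. Also open, from the compounds shown here alone, is whether any group at this place can bring the number clearly below that of compound 1, which is 43300 nM.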